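Cytotoxicity of Two Oxime Ether Pairs on Vero Cells

The compounds below may be only part of what the source reports. "The series", "measured", "known", "first", "only" and "open" are said of these compounds alone.

Measured so far, in an ADME assay on Vero cells (Chlorocebus sabaeus) for cytotoxicity; a higher number here means that more compound is tolerated, a lower number that less compound is tolerated:
Compound 1 `CO/N=C(\C)CCN1CCN(c2nc(=O)c3cc(C(F)(F)F)cc([N+](=O)[O-])c3s2)CC1` gives only a limit, > 64 ug/mL.
Compound 2 `CCO/N=C(\C)CCN1CCN(c2nc(=O)c3cc(C(F)(F)F)cc([N+](=O)[O-])c3s2)CC1` gives only a limit, > 64 ug/mL.
Compound 3 `CON=C1CCC(CN2CCN(c3nc(=O)c4cc(C(F)(F)F)cc([N+](=O)[O-])c4s3)C[C@@H]2C)CC1` gives only a limit, > 64 ug/mL.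

Compound 2 differs from compound 1 by methyl in place of hydrogen on a saturated chain carbon bound to an oxygen on an unsaturated carbon. The step that the two limits leave unreadable from compound 1 to compound 2 cannot be read, since both values sit at the limit of > 64 ug/mL in this assay, at which 3 of the 3 values shown sit. Compound 4 `CCON=C1CCC(CN2CCN(c3nc(=O)c4cc(C(F)(F)F)cc([N+](=O)[O-])c4s3)C[C@@H]2C)CC1` differs from compound 3 by methyl in place of hydrogen on a saturated chain carbon bound to an oxygen on an unsaturated carbon, the same change as between compound 1 and compound 2. How the core of compound 3 differs from the core of compound 1 is not broken down here. The step that the limit leaves unreadable from compound 3 to compound 4 is expected to be small, resting on the unreadable step that the two limits leave unreadable from compound 1 to compound 2 and on (the limit of > 64 ug/mL in this assay, at which 3 of the 3 values shown sit), where every value shown sits. For compound 4 the estimate in this assay is 80 ug/mL, between 40 ug/mL and 200 ug/mL, most probably again reported only as a limit.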

Compound 4, half-maximal cytotoxic concentration: > 64 ug/mL
Compound 4: only a limit was reported; the forecaster's own chance of this, stated with the estimate: 85%; the middle value is on the limit's open side.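

Compound 3 and compound 4 give no readable step, because both values are only limits: the limit of > 64 ug/mL in this assay, at which 4 of the 4 values shown sit.

Going by these compounds, how far any of the four compounds lies past that limit, and so whether methoxy to ethoxy matters in this assay, stays open.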